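Chalcone Analogues: Trimming the Hydroxy-Methoxyphenyl Head

A few compounds are considered here, and "the series" means these few. Any claim that something is new, unique, unknown or untested is made for them only; others in the source may bear on it.

Of the compounds shown here, two of a shared core have been measured in a functional assay on SK-MEL-28 cells (Homo sapiens) for inhibition; on this read-out lower numbers stand for stronger inhibition of growth and higher numbers for weaker inhibition of growth. Compound 1, `COc1cc(/C=C/C(=O)c2cccc(-n3cc(-c4ccc(Cl)cc4)[nH]c3=O)c2)cc(OC)c1OC`, gives 10900 nM. Compound 2, `COc1cc(/C=C/C(=O)c2cccc(-n3cc(-c4ccccc4)[nH]c3=O)c2)ccc1O`, gives 1850 nM. On these two numbers compound 2 stands lowest; its nearest neighbour is compound 1, whose number is higher by a margin that lies beyond the usual scatter of repeated measurements.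

Compound 3, `O=C(/C=C/c1cccc(O)c1)c1cccc(-n2cc(-c3ccccc3)[nH]c2=O)c1`, has not yet been measured. It differs from compound 2 in one place: 3-hydroxyphenyl in place of 4-hydroxy-3-methoxyphenyl on a double-bonded chain carbon bound to a double-bonded chain carbon. Within the data shown here, no measured pair shows this same change, so there is no directly comparable step to lean on. The step from compound 2 to compound 3 is expected to be small, at most a modest weakening, and probably not beyond the scatter: a 1.6-fold higher number from compound 2 to compound 3 (0.21 log units; within the scatter). Compound 3 is therefore expected to give about 3000 nM in this assay, with a likely range from 1000 nM to 9000 nM.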

Compound 3, concentration for 50% growth inhibition: 5630 nM
Estimate against measurement, compound 3: 1.9-fold (0.27 log units) below; low and high end bracket the measured number.
By their numbers in this assay, from the lowest: compound 2; then compounds 3 and 1 (each within the scatter of the next).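

In this assay, putting 3-hydroxyphenyl in place of 4-hydroxy-3-methoxyphenyl on a double-bonded chain carbon bound to a double-bonded chain carbon gives a 3.0-fold higher number from compound 2 to compound 3 (0.48 log units; beyond the scatter) and so shows that growth inhibition responds to this group. Among these compounds, compound 1 differs from compound 2 in more than one place, so only this new pair isolates a change here, and the 4-hydroxy-3-methoxyphenyl group is the better of the two groups compared. The swap alters the methoxy group and the place of the hydroxy group together, and the data give no reason for the weakening.

Which of those two alterations carries the loss remains open, as this single step cannot separate them. Also open, as far as these compounds go, is how a plain phenyl, or an amine or a carboxylic acid on that ring, would compare.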